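Chain length and cytotoxicity, from compound 3 to compound 4

The source may hold more compounds than are shown below. What is called first, only, known or untested is meant among the compounds shown, and "the series" means these compounds.

In a functional assay on CCRF-CEM cells (Homo sapiens) for cytotoxicity (a lower number here means that less compound is tolerated, a higher number that more compound is tolerated), compound 1 `CC(=O)Nc1nc(N)nc2c1ncn2[C@H]1CO[C@@H](CO)O1` reads > 100000 nM as a limit of the assay. Compound 2 `CCCCCC(=O)Nc1nc(N)nc2c1ncn2[C@H]1CO[C@@H](CO)O1` reads > 100000 nM as a limit too. Among the compounds with values here, compound 3 `CCCCCCCCCC(=O)Nc1nc(N)nc2c1ncn2[C@H]1CO[C@@H](CO)O1` at 65000 nM gives the only true number of the three. Compound 4 `CCCCCCCCCCCCCC(=O)Nc1nc(N)nc2c1ncn2[C@H]1CO[C@@H](CO)O1` differs from it through butyl in place of hydrogen on a saturated chain carbon, nine bonds along the chain from a carbonyl carbon and so has a longer chain. Earlier chain growth bears on this through an at least 1.5-fold lower number from compound 1 to compound 3 (0.18 log units; that floor lies within the scatter) and through an at least 1.5-fold lower number from compound 2 to compound 3 (0.18 log units; that floor lies within the scatter) as floors only, while a step that the two limits leave unreadable from compound 1 to compound 2 offers no usable size. A modest further drop is therefore expected, with a 2.2-fold lower number from compound 3 to compound 4 (0.34 log units; beyond the scatter) as the estimated step in this assay and a limit reading still possible. In this assay the estimated value for compound 4 is 30000 nM with an expected range of 10000 nM to 90000 nM around it.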

Compound 4, half-maximal cytotoxic concentration: 4600 nM
The estimate for compound 4 lay 6.5-fold (0.81 log units) above the measured number, and the stated range ends above it.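

In this assay, butyl in place of hydrogen, nine bonds along the chain from a carbonyl carbon, gives a step of readable size, a 14-fold lower number from compound 3 to compound 4 (1.15 log units; beyond the scatter). Octyl in place of hydrogen, five bonds along the chain from a carbonyl carbon, gives an at least 21-fold lower number from compound 2 to compound 4 (1.33 log units; beyond the scatter). The steps to compound 3 had offered only floors within the scatter, whereas this change now shows a floor beyond it on one of two cores: the same change on two cores in this assay, an at least 1.5-fold lower number (0.18 log units; that floor lies within the scatter) from compound 1 to compound 3 and an at least 21-fold lower number (1.33 log units; beyond the scatter) from compound 2 to compound 4; the limit leaves it open whether they differ. The compounds shown leave open whether a longer chain would lower the number further. They also leave open what an amine or a carboxylic acid at this place would do.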